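The source may hold more compounds than are shown below. What is called first, only, known or untested is meant among the compounds shown, and "the series" means these compounds.

Of the compounds shown here, three from this series have been tested, all sharing one core that carries an indole-type unit on a bicyclic ester. Compound 1 `COC(=O)[C@@]1(C)CCC=C2[C@@H]1CC[C@@H](C)[C@]2(C)Cc1c[nH]c2ccc(C)cc12` gives 20000 nM in a functional assay on T47D cells (Homo sapiens) for inhibition, read by sulforhodamine B assay, with a stated time of 48 h; a higher number here means a weaker inhibitor of growth, a lower number a stronger inhibitor of growth. Compound 2 `COC(=O)[C@@]1(C)CCC=C2[C@@H]1CC[C@@H](C)[C@]2(C)Cc1c[nH]c2ccc(Br)cc12` differs from compound 1 by bromo in place of methyl on an aromatic carbon, and in this assay compound 2 gives 16000 nM; the step is a 1.3-fold lower number from compound 1 to compound 2 (0.10 log units; within the scatter), so the exchange of one group for the other at that place leaves the growth inhibition essentially where it was. Compound 3 `COC(=O)[C@@]1(C)CCC=C2[C@@H]1CC[C@@H](C)[C@]2(C)Cc1c[nH]c2c(C)cccc12` is built from the same atoms as compound 1, joined differently, and the difference between the two cores is not broken down here; in this assay compound 3 gives 18000 nM, close to compound 1 and compound 2.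

Compound 4 `COC(=O)[C@@]1(C)CCC=C2[C@@H]1CC[C@@H](C)[C@]2(C)Cc1c[nH]c2c(Br)cccc12` has not yet been measured. It differs from compound 3 by bromo in place of methyl on an aromatic carbon. Among the compounds with values here, this is the same kind of change as the one from compound 1 to compound 2, but not the same: there the place was meta to a fused ring and para to a fused ring, whereas here it is ortho to a fused ring and meta to a fused ring. Since the earlier step of a 1.3-fold lower number from compound 1 to compound 2 (0.10 log units; within the scatter) stayed within the scatter, a similarly small step is expected, a 1.2-fold lower number from compound 3 to compound 4 (0.08 log units; within the scatter). On that basis compound 4 is estimated at 15000 nM, with a plausible range from 7000 nM to 32000 nM.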

Compound 4, concentration for 50% growth inhibition: 24000 nM
Beside the measured number, compound 4's estimate is 1.6-fold (0.20 log units) below it; the range from low to high includes it.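

In this assay, placing bromo instead of methyl at the position ortho to a fused ring and meta to a fused ring gives a 1.3-fold higher number from compound 3 to compound 4 (0.12 log units; within the scatter), so here too the exchange leaves the growth inhibition essentially where it was. Set side by side, the two steps cannot be told apart: the same change on two cores in this assay, a 1.3-fold lower number (0.10 log units; within the scatter) from compound 1 to compound 2 and a 1.3-fold higher number (0.12 log units; within the scatter) from compound 3 to compound 4, 1.7-fold (0.22 log units) apart, within the scatter of two such steps. This shows that, across these two pairs, the exchange of methyl for bromo carries from one core to the other as a change too small to read, but it does not show that the two places respond identically, as a small real difference could still lie hidden in the scatter, and two pairs cannot establish a rule for the whole series.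

From the compounds shown here alone, all four compounds carry either methyl or bromo on the aromatic ring, so it remains open whether a different kind of group there, such as an amine or a carboxylic acid, would move the number beyond the scatter. Also open, going by these compounds, is how the growth inhibition would respond if the methyl ester of the shared core gave way to a carboxylic acid or an amide.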